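This account rests on a few compounds, and the source may have more. Where it says the series, first, only, none or still open, it means among the compounds named here.

Measured compounds in a functional assay on A549 cells (Homo sapiens) for cytotoxicity, read by MTT assay, with a stated time of 72 h; a lower number here means a stronger inhibitor, a higher number a weaker inhibitor:
- compound 1 `O=C(Nc1nc2ccc(F)cc2s1)c1cn(-c2ccccc2)nc1-c1ccccc1` gives 10200 nM
- compound 2 `O=C(Nc1nc2ccc(F)cc2s1)c1cn(-c2ccccc2)nc1-c1ccc(Cl)cc1` gives 8860 nM

The two measured compounds differ in one place, chloro in place of hydrogen on an aromatic carbon, and the step of a 1.2-fold lower number from compound 1 to compound 2 (0.06 log units; within the scatter) is within the scatter. Compound 2 and compound 1 therefore lie within the scatter of each other in this assay, and neither can be called the stronger on these numbers.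

Compound 3 `COc1ccc(-c2nn(-c3ccccc3)cc2C(=O)Nc2nc3ccc(F)cc3s2)cc1` takes the next step from compound 2: methoxy in place of chloro on an aromatic carbon. For the measured compounds named here, only the step of a 1.2-fold lower number from compound 1 to compound 2 (0.06 log units; within the scatter) bears on this position, and it shows that changing the substituent at this aromatic carbon left the number essentially unmoved. Nothing measured here points in either direction for a methoxy at the same place. The expectation for compound 3 in this assay is therefore a step of a 1.0-fold higher number from compound 2 to compound 3 (0.01 log units; within the scatter), none beyond the scatter. Compound 3 is estimated at 9000 nM, with a range from 3000 nM to 27000 nM.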

Compound 3, half-maximal inhibitory concentration: 7560 nM
The estimate for compound 3 lay 1.2-fold (0.08 log units) above the measured number; the measured number falls inside the stated range.
By their numbers in this assay, from the lowest: compounds 3, 2 and 1 (each within the scatter of the next).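

In this assay, the change from 4-chlorophenyl to 4-methoxyphenyl gives a 1.2-fold lower number from compound 2 to compound 3 (0.07 log units; within the scatter), and methoxy set against hydrogen at the same place gives a 1.3-fold lower number from compound 1 to compound 3 (0.13 log units; within the scatter). The earlier pair had tested only chloro at this aromatic carbon, para to a large group; methoxy, which differs from chloro in its atoms and carries a hydrogen-bond acceptor, now also leaves all three compounds within the scatter of one another. No supporting evidence accompanies these numbers to explain this result.

From the compounds shown here alone, whether an amine, a carboxylic acid or a longer chain at this position would also stay within the scatter remains open. So does whether changes elsewhere on the shared core would move the number beyond the scatter.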